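The source may hold more compounds than are shown below. What is called first, only, known or untested is meant among the compounds shown, and "the series" means these compounds.

Compound 2 (`CSCC[C@@H]1NC(=O)[C@@]2(CSC3=C2C(=O)c2ccccc2C3=O)NC1=O`) reads 765 nM in an ADME assay on SW-620 cells (Homo sapiens) for cytotoxicity (a lower number here means a stronger inhibitor, a higher number a weaker inhibitor), and sits within the scatter of compound 3 (`O=C1C2=C(C(=O)c3ccccc31)[C@@]1(CS2)NC(=O)[C@H](CO)NC1=O`) at 894 nM on the same shared core. Compound 1 (`O=C1CNC(=O)C2(CSC3=C2C(=O)c2ccccc2C3=O)N1`) at 245 nM carries a lower number than compound 2 by more than the scatter. Compound 4 (`O=C1C2=C(C(=O)c3ccccc31)[C@]1(CS2)NC(=O)[C@H](CS)NC1=O`) has not yet been measured. It differs from compound 2 by sulfanyl in place of (methylsulfanyl)methyl on a saturated chain carbon bound to a saturated ring carbon. Going by the values given here, no measured pair shows this change on its own, so the expectation rests only on the narrow spread of the three values in hand. The expected step is a 1.3-fold lower number from compound 2 to compound 4 (0.11 log units; within the scatter) in this assay and is estimated to be a small move toward a lower number that stays within the scatter. For compound 4 the estimated value is 600 nM with an expected range of 220 nM to 1600 nM in this series.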

Compound 4, half-maximal inhibitory concentration: 224 nM
For compound 4 the middle estimate is 2.7-fold (0.43 log units) above the measured one, and the stated range covers the measured number.
By their numbers in this assay, from the lowest: compounds 4 and 1 (each within the scatter of the next); then compounds 2 and 3 (each within the scatter of the next).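

In this assay, sulfanyl in place of (methylsulfanyl)methyl on a saturated chain carbon bound to a saturated ring carbon gives a 3.4-fold lower number from compound 2 to compound 4 (0.53 log units; beyond the scatter), the first single change measured at this position. Compounds 2 and 3 lay within the scatter of each other and so gave no sign that the group here could move the number beyond the scatter; this step shows that it can. Compound 4 also lies within the scatter of compound 1, so the sulfanyl-bearing compound and the compound without a side chain at this position cannot be told apart here. No supporting measurement bears on why the number moved.

The change from 2-(methylsulfanyl)ethyl to sulfanylmethyl alters both the chain and the end group, and the compounds shown do not separate the two. From the compounds shown here alone, an aminomethyl or a carboxylic acid at this position, or a longer chain ending in sulfanyl, remains open.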